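From quinolin-5-yl to 3,5-dimethyl-1,2-oxazol-4-yl in compound 4

The compounds below may be only part of what the source reports. "The series", "measured", "known", "first", "only" and "open" are said of these compounds alone.

In a functional assay on MDA-MB-436 cells (Homo sapiens) for antiproliferative activity, read by MTT assay, with a stated time of 48 h (a lower number here means a stronger inhibitor, a higher number a weaker inhibitor), compound 1 (`C=CS(=O)(=O)N1CCN(c2ncnc3sc(-c4cccc5ncccc45)cc23)CC1`) gives 25900 nM. Compound 2 (`C=CS(=O)(=O)N1CCN(c2ncnc3sc(-c4cn(S(=O)(=O)c5ccccc5)c5ccccc45)cc23)CC1`) gives 38000 nM, and compound 3 (`C=CS(=O)(=O)N1CCN(c2ncnc3sc(-c4cnn(Cc5ccccc5)c4)cc23)CC1`) gives 18300 nM. The value of compound 1 lies within the usual scatter of each of the other two, so all three sit in one narrow band even though they carry quite different groups at the same place on the shared core.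

Compound 4 (`C=CS(=O)(=O)N1CCN(c2ncnc3sc(-c4c(C)noc4C)cc23)CC1`) has 3,5-dimethyl-1,2-oxazol-4-yl in place of quinolin-5-yl on an aromatic carbon, next to the ring sulfur. The change is this: 3,5-dimethyl-1,2-oxazol-4-yl in place of quinolin-5-yl on an aromatic carbon. For the measured compounds named here, no two measured compounds differ in one place only, so no direct step guides the expectation, and the band around compound 1 at 25900 nM is the only evidence. No step beyond the scatter is expected, in either direction. The estimated change is a 1.2-fold lower number from compound 1 to compound 4 (0.07 log units; within the scatter). For compound 4 the expected value is 22000 nM, with an estimated range from 9000 nM to 50000 nM.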

Compound 4, half-maximal inhibitory concentration: 34600 nM
Compound 4: middle estimate off by 1.6-fold (0.20 log units), on the low side, within the range that was stated.
By their numbers in this assay, from the lowest: compounds 3, 1, 4 and 2 (each within the scatter of the next, the first and the last beyond it).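

For the compounds shown here, the step of a 1.3-fold higher number from compound 1 to compound 4 (0.13 log units; within the scatter), read in this assay, is the first comparison in this set between two compounds that differ in one place only, and it lies within the scatter. It shows that a single five-membered aromatic ring with two hetero atoms, 3,5-dimethyl-1,2-oxazol-4-yl, can stand in place of the two fused six-membered rings of quinolin-5-yl, on an aromatic carbon next to the ring sulfur, with fewer heavy atoms and no step beyond the scatter. No measurement offered here accounts for this result.

On these data alone, whether an amine or a carboxylic acid on an aromatic ring at this place would move the number beyond the scatter remains open. Also open, as far as these compounds go, is whether a compound with a small group such as methyl at this place would stay in the same band.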